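Swapping the Aryl Group on the Triazole Nitrogen: Compound 4

The compounds below may be only part of what the source reports. "The series", "measured", "known", "first", "only" and "open" are said of these compounds alone.

Results in a functional assay on PANC-1 cells (Homo sapiens) for inhibition, read by MTT assay, with a stated time of 24 h (a lower number here means a stronger inhibitor, a higher number a weaker inhibitor), so far:
Compound 1, `CC1(C)[C@H]2CC[C@]1(C)N(Cc1cn(-c3cccc(Cl)c3)nn1)C(=O)C2`: 260 nM
Compound 2, `CC1(C)[C@H]2CC[C@]1(C)N(Cc1cn(-c3ccc(Cl)cc3)nn1)C(=O)C2`: 440 nM
Compound 3, `CC1(C)[C@H]2CC[C@]1(C)N(Cc1cn(-c3ccccc3Br)nn1)C(=O)C2`: 280 nM

Compound 2 gives the highest of the three numbers, but its distance to compound 3 is a 1.6-fold lower number from compound 2 to compound 3 (0.20 log units; within the scatter) and its distance from compound 1 is a 1.7-fold higher number from compound 1 to compound 2 (0.23 log units; within the scatter), so the three compounds cannot be ordered on this assay. Compound 4, `Cc1cccc(-n2cc(CN3C(=O)C[C@@H]4CC[C@@]3(C)C4(C)C)nn2)c1`, differs from compound 2 by 3-methylphenyl in place of 4-chlorophenyl on an aromatic nitrogen. The two measured steps that bear on it are exchanges of the aryl group on the same nitrogen, and both stayed within the scatter. Compound 4 is therefore expected to show no step beyond the scatter, a 1.3-fold lower number from compound 2 to compound 4 (0.12 log units; within the scatter). Compound 4 is estimated at 330 nM, with a range from 150 nM to 700 nM.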

Compound 4, half-maximal inhibitory concentration: 240 nM
Compound 4: the middle estimate sits 1.4-fold (0.14 log units) above what was measured; low and high end bracket the measured number.
By their numbers in this assay, from the lowest: compounds 4, 1, 3 and 2 (each within the scatter of the next).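

Compound 4 carries no halogen on its aryl group, yet in this assay methyl in place of chloro on an aromatic carbon stays within the scatter (a 1.1-fold lower number from compound 1 to compound 4 (0.03 log units; within the scatter)). The exchanges for 4-chlorophenyl (a 1.8-fold lower number from compound 2 to compound 4 (0.26 log units; within the scatter)) and 2-bromophenyl (a 1.2-fold lower number from compound 3 to compound 4 (0.07 log units; within the scatter)) also stay within it, so the four aryl groups on this nitrogen cannot be ordered, and no available evidence bears on this result.

The compounds shown leave open whether an amine or a carboxylic acid on the phenyl ring would give a step beyond the scatter. They also leave open how 2-methylphenyl and 4-methylphenyl would compare with 3-methylphenyl.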